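This account rests on a few compounds, and the source may have more. Where it says the series, first, only, none or still open, it means among the compounds named here.

Values in a functional assay on HeLa cells (Homo sapiens) for cytotoxicity, read by MTT assay; a lower number here means a stronger inhibitor, a higher number a weaker inhibitor:
- compound 1 `CC[C@@](C)(O)CC(=O)O[C@H](CC=C(C)C)C1=CC(=O)c2c(O)ccc(O)c2C1=O`: 17900 nM
- compound 2 `CCCC(C)(O)CC(=O)O[C@H](CC=C(C)C)C1=CC(=O)c2c(O)ccc(O)c2C1=O`: 72000 nM

Compound 2 holds the higher number of the two. Compound 3 `CCC(CO[C@H](CC=C(C)C)C1=CC(=O)c2c(O)ccc(O)c2C1=O)OC` differs from it by 2-methoxybutyl in place of (2-hydroxy-2-methylpentyl)carbonyl on an oxygen on a saturated carbon. Going by the values given here, only one measured step bears on this, a 4.0-fold higher number from compound 1 to compound 2 (0.60 log units; beyond the scatter), a modest change within the group that leaves. Among the compounds with values here, no measured step covers replacing that whole group, so the uncertainty is wide. Within the data shown here, a modest move to a lower number in this assay is expected, with compound 1 at 17900 nM as the only guide. The expected move is a 2.4-fold lower number from compound 2 to compound 3 (0.38 log units; beyond the scatter). The estimate for compound 3 is 30000 nM, ranging from 8000 nM to 100000 nM.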

Compound 3, half-maximal inhibitory concentration: 63500 nM
Estimate against measurement, compound 3: 2.1-fold (0.33 log units) below; the measured number falls inside the stated range.
By their numbers in this assay, from the lowest: compound 1; then compounds 3 and 2 (each within the scatter of the next).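

In this assay, 2-methoxybutyl in place of (2-hydroxy-2-methylpentyl)carbonyl gives a 1.1-fold lower number from compound 2 to compound 3 (0.05 log units; within the scatter), so on this oxygen the whole group can be exchanged, losing the carbonyl and the hydrogen-bond donor, with no change beyond the scatter. The same entering group set against the (2-hydroxy-2-methylbutyl)carbonyl group gives a 3.5-fold higher number from compound 1 to compound 3 (0.55 log units; beyond the scatter), which leaves compound 1 apart from both compound 2 and compound 3. No measurement available here accounts for either step.

Open, from the compounds shown here alone, is how an amine or a carboxylic acid at the end of this group would read out. Also open, going by these compounds, is whether a chain longer than 2-methoxybutyl would stay level with compound 3.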